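The source may report more compounds than this note shows. Statements on the series, on what has been measured and on what is new or still open speak of the compounds shown alone.

In an ADME assay (liver) for metabolic stability, with Liver microsome (Rattus norvegicus) as the target, using microsomes and NADPH, with a stated time of 30 min, at 37 degrees C, tested at 1 uM (a higher number here means faster removal of the compound, a lower number slower removal), compound 1 (`CC(O)(c1ccc(-c2ccc(S(=O)(=O)c3ccc(N)nc3)cc2)cc1)C(F)(F)F`) gives < 14 mL.min-1.g-1, a limit of the assay and not a number. Compound 3 (`Nc1ccc(S(=O)(=O)c2ccc(-c3ncc(C(O)(C(F)(F)F)C(F)(F)F)cn3)cc2)cn1`) gives < 14 mL.min-1.g-1, again a limit. Compound 2 (`Nc1ccc(S(=O)(=O)c2ccc(-c3ccc(C(O)(C(F)(F)F)C(F)(F)F)cn3)cc2)cn1`) gives < 14 mL.min-1.g-1, also only a limit, so it has no number of its own to stand on. Compound 4 (`N#Cc1cc(C(O)(C(F)(F)F)C(F)(F)F)cnc1-c1ccc(S(=O)(=O)c2ccc(N)nc2)cc1`) carries cyano in place of hydrogen on an aromatic carbon of the six-membered aromatic ring with 1 nitrogen, ortho to a large group: cyano in place of hydrogen on an aromatic carbon. Going by the values given here, no measured step speaks to this change, and none beyond the scatter is expected in this assay. The expected step that the limit leaves unreadable from compound 2 to compound 4 therefore stays small. For compound 4 the estimate is 10 mL.min-1.g-1, with an expected range of 5 mL.min-1.g-1 to 20 mL.min-1.g-1.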

Compound 4, intrinsic clearance in microsomes: 27 mL.min-1.g-1
Estimate against measurement, compound 4: 2.7-fold (0.43 log units) below; the measured number lies above the stated range.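

In this assay, cyano in place of hydrogen at this position, ortho to a large group, gives the first result in the series that is a number and not a limit, with an at least 1.9-fold higher number from compound 2 to compound 4 (0.28 log units; that floor lies within the scatter). Only this floor can be read, so the full size of the step stays unknown, and no other step can be read: the limit of < 14 mL.min-1.g-1 in this assay, at which 3 of the 4 values shown sit.

From the compounds shown here alone, whether an amine or a methyl group at this position would also leave the limit remains open. Also open, going by these compounds, is whether cyano would do the same on the cores of compound 1 and compound 3.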